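Two Cores, One Aryl Exchange, Weak Antiproliferative Activity

A few compounds are considered here, and "the series" means these few. Any claim that something is new, unique, unknown or untested is made for them only; others in the source may bear on it.

Compound 1 `CC1(C)C/C(=N\OC(=O)c2cccc(NC(=O)c3cccc(F)c3)c2)c2c(-c3cccc(F)c3)noc2C1` and compound 2 `CC1(C)C/C(=N\OC(=O)c2cccc(NC(=O)c3cccc(F)c3)c2)c2c(noc2-c2cccc(F)c2)C1` are built from the same atoms joined differently; the difference between the two cores is not broken down here. In a functional assay on MCF7 cells (Homo sapiens) for antiproliferative activity, read by MTT assay, with a stated time of 72 h (a higher number here means a weaker inhibitor, a lower number a stronger inhibitor), compound 1 gives 25000 nM. For compound 2, this assay yields only a limit, > 25000 nM. Compound 3 `COc1ccc(-c2noc3c2/C(=N/OC(=O)c2cccc(NC(=O)c4cccc(F)c4)c2)CC(C)(C)C3)cc1OC` carries a 3,4-dimethoxyphenyl in place of the 3-fluorophenyl of compound 1 (3,4-dimethoxyphenyl in place of 3-fluorophenyl on an aromatic carbon). In this assay compound 3 likewise reaches only a limit, > 25000 nM. The step of a number no lower from compound 1 to compound 3 (the limit leaves the size open) therefore leaves its size open, and the limit of > 25000 nM in this assay, at which 2 of the 3 values shown sit, shows where two of the three results rest. Compound 4 `COc1ccc(-c2onc3c2/C(=N/OC(=O)c2cccc(NC(=O)c4cccc(F)c4)c2)CC(C)(C)C3)cc1OC` stands to compound 2 as compound 3 stands to compound 1 (3,4-dimethoxyphenyl in place of 3-fluorophenyl on an aromatic carbon); it is the same kind of change, though here the carbon bearing the group is next to the ring oxygen and two ring bonds from the ring nitrogen, whereas in compound 3 it is next to the ring nitrogen and two ring bonds from the ring oxygen. Compound 4 is expected to fall at 30000 nM, a step that the limit leaves unreadable from compound 2 to compound 4, because a number no lower from compound 1 to compound 3 (the limit leaves the size open) ran the same way on the other core.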

Compound 4, half-maximal inhibitory concentration: > 25000 nM
Compound 4 was reported as a limit (the forecaster's own chance of this, stated with the estimate: 85%); the middle value lies beyond the limit too.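

In this assay compound 4 gives only a limit, > 25000 nM. With compound 2 also resting on a limit, no step can be read between compound 2 and compound 4: the limit of > 25000 nM in this assay, at which 3 of the 4 values shown sit.

The compounds shown leave open whether 3,4-dimethoxyphenyl in place of 3-fluorophenyl changes the antiproliferative activity on either core, and by how much.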